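Acetyl for tert-butylcarbamoyl on the piperidine nitrogen

The source may hold more compounds than are shown below. What is called first, only, known or untested is meant among the compounds shown, and "the series" means these compounds.

Measured so far:
Compound 1 `Cn1cncc1CN1CC(N(CC2CCN(C(=O)NC(C)(C)C)CC2)S(=O)(=O)c2ccccn2)Cc2cc(C#N)ccc21`: 0.6 10^-6 cm/s
Compound 2 `Cn1cnc(S(=O)(=O)N2CCC(CN(C3Cc4cc(C#N)ccc4N(Cc4cncn4C)C3)S(=O)(=O)c3ccccn3)CC2)c1`: 0.1 10^-6 cm/s
Compound 3 `Cc1noc(C)c1CN(C1Cc2cc(C#N)ccc2N(Cc2cncn2C)C1)S(=O)(=O)c1ccccn1`: 8 10^-6 cm/s

Compound 1 stands second highest of the three numbers in an ADME assay on Caco-2 cells (Homo sapiens) for permeability, in the apical to basolateral direction; a lower number here means that the compound crosses the layer more slowly, a higher number that the compound crosses the layer faster. Its nearest neighbour is compound 2, reached by a 6.0-fold lower number from compound 1 to compound 2 (0.78 log units; beyond the scatter), where the ring nitrogen carries (1-methyl-1H-imidazol-4-yl)sulfonyl in place of (tert-butyl)carbamoyl. Compound 3, which lacks the piperidine arm altogether, gives 8 10^-6 cm/s, whereas compound 1 gives 0.6 10^-6 cm/s, a gap beyond the scatter.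

Compound 4 `CC(=O)N1CCC(CN(C2Cc3cc(C#N)ccc3N(Cc3cncn3C)C2)S(=O)(=O)c2ccccn2)CC1` keeps the whole frame of compound 1 and differs only at the carbonyl carbon: methyl in place of (tert-butyl)amino on a carbonyl carbon. The change, cut one bond further out, reads (tert-butyl)carbamoyl to acetyl.

For the measured compounds named here, only one measured step touches this part of the molecule, the one from compound 1 to compound 2, and it exchanges the carbamoyl for a sulfonyl group rather than trimming it; no pair yet shows methyl in place of (tert-butyl)amino. The data therefore give no direct guide, and the expectation is a small rise or none beyond the scatter, expressed as a 2.5-fold higher number from compound 1 to compound 4 (0.40 log units; beyond the scatter).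

Compound 4 is estimated at 1.5 10^-6 cm/s, between 0.4 10^-6 cm/s and 5 10^-6 cm/s.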

Compound 4, apparent permeability: 0.5 10^-6 cm/s
The estimate for compound 4 lay 3.0-fold (0.48 log units) above the measured number; the range from low to high includes it.
By their numbers in this assay, from the lowest: compound 2; then compounds 4 and 1 (each within the scatter of the next); then compound 3.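

In this assay, the first direct trim of this cap gives a 1.2-fold lower number from compound 1 to compound 4 (0.08 log units; within the scatter): methyl in place of (tert-butyl)amino on a carbonyl carbon loses the bulk of the group and its hydrogen-bond donor, yet the two compounds cannot be told apart. What sets the low and high numbers apart in this small set therefore lies elsewhere than in the size of the carbonyl substituent, since the sulfonyl cap still stands apart with a 5.0-fold higher number from compound 2 to compound 4 (0.70 log units; beyond the scatter), and the arm as a whole still carries a large gap, with a 16-fold lower number from compound 3 to compound 4 (1.20 log units; beyond the scatter) for 1-acetylpiperidin-4-yl in place of 3,5-dimethyl-1,2-oxazol-4-yl on a saturated chain carbon bound to a sulfonamide nitrogen. No supporting measurement is available to explain any of these steps.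

The compounds shown leave open whether a free secondary amine on the piperidine nitrogen, or a carboxylic acid on the acetyl methyl, would shift the number at all. They also leave open whether a smaller ring such as an azetidine in place of the piperidine, with the acetyl kept, would bring the number closer to that of compound 3.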